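A few compounds are considered here, and "the series" means these few. Any claim that something is new, unique, unknown or untested is made for them only; others in the source may bear on it.

Series notes. Compound 1 `C#CCn1cc(C(=O)NCCCOC(=O)CNC(=O)OC(C)(C)C)c(=O)c2cccnc21` and compound 2 `C#CCn1cc(C(=O)NCCCOC(=O)[C@H](C)NC(=O)OC(C)(C)C)c(=O)c2ccc(Cl)nc21` share the same core and differ elsewhere in more than one place. In a functional assay on K562 cells (Homo sapiens) for cytotoxicity, read by MTT assay, with a stated time of 72 h (on this read-out lower numbers stand for stronger inhibition and higher numbers for weaker inhibition), compound 1 reaches only the limit of the assay, > 10000 nM. In this assay compound 2 likewise stops at the limit, > 10000 nM, so no finished number is known for it. Both results sit at the limit of > 10000 nM in this assay, at which 2 of the 2 values shown sit; compound 2 therefore stands with compound 1 at the edge of what the assay reports, and nothing separates the two. Compound 3 `C#CCn1cc(C(=O)N[C@@H](C)CCOC(=O)[C@H](C)NC(=O)OC(C)(C)C)c(=O)c2ccc(Cl)nc21` is the next member. It differs from compound 2 by methyl in place of hydrogen on a saturated chain carbon bound to an amide-type nitrogen and a saturated chain carbon. Among the measured compounds shown here, no measured pair shows a change of this kind, and both measured compounds are limits, so the step has no precedent among the numbers. The step from compound 2 to compound 3 is expected to be none beyond the scatter, a step that the limit leaves unreadable from compound 2 to compound 3. For compound 3 the expected value in this assay is 20000 nM, with a range of 5000 nM to 80000 nM, and the assay is expected most likely to report only a limit again.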

Compound 3, half-maximal inhibitory concentration: > 10000 nM
Compound 3 was reported as a limit; the forecaster's own chance of this, stated with the estimate: 80%; the middle value lies beyond the limit too.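

In this assay compound 3 gives only the limit > 10000 nM and no finished number. Compound 2 also stands at a limit, so no step can be read between compound 2 and compound 3. The compounds shown leave open how strong any of them is, since none has a finished number: the limit of > 10000 nM in this assay, at which 3 of the 3 values shown sit.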